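Methoxy added to the benzyl group of a weak inhibitor

The compounds below may be only part of what the source reports. "The series", "measured", "known", "first", "only" and "open" are said of these compounds alone.

Compound 1, `O=C(Nc1cccc(C(F)(F)F)c1)c1c(O)nnn1CC1CC1`, gives in an assay on isolated protein for inhibition of cytochrome c oxidase subunit 2 (Homo sapiens), read by ELISA (on this read-out higher numbers stand for weaker inhibition and lower numbers for stronger inhibition), the value > 100000 nM, which is a limit of the assay and not a number.
Compound 2, `O=C(Nc1cccc(C(F)(F)F)c1)c1c(O)nnn1Cc1ccccc1`, gives in this assay the value > 100000 nM, again a limit of the assay.

Going by the values given here, compound 2 therefore stands only at a limit in this assay, and the one other value shown is a limit as well. The step that the two limits leave unreadable from compound 1 to compound 2 cannot be read, since both ends sit at the same limit, as the limit of > 100000 nM in this assay, at which 2 of the 2 values shown sit, records.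

Compound 3, `COc1ccc(Cn2nnc(O)c2C(=O)Nc2cccc(C(F)(F)F)c2)cc1`, differs from compound 2 by methoxy in place of hydrogen on an aromatic carbon. Among the compounds with values here, no measured step bears on this change: the only step available, from compound 1 to compound 2, is unreadable, so it gives no direction and no size to expect. With both neighbours at the limit, the expectation for compound 3 in this assay is that it most likely also returns a limit, and the estimated step of a number no higher from compound 2 to compound 3 (the limit leaves the size open) is taken as none beyond the scatter. The estimate for compound 3 is 100000 nM, within a range from 30000 nM to 300000 nM.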

Compound 3, half-maximal inhibitory concentration: > 100000 nM
Compound 3: a limit, no number; the forecaster's own chance of this, stated with the estimate: 85%; the middle value sits exactly at the limit.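

Going by these compounds alone, no step between compound 1, compound 2 and compound 3 can be read, since each compound gives only a limit of the assay and not a number: the limit of > 100000 nM in this assay, at which 3 of the 3 values shown sit. The compounds shown leave open how strongly any of the three inhibits, and whether exchanging cyclopropyl, phenyl and 4-methoxyphenyl changes inhibition at all.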